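A few compounds are considered here, and "the series" means these few. Any claim that something is new, unique, unknown or untested is made for them only; others in the source may bear on it.

Measured in a functional assay on HT cells (Homo sapiens) for antiproliferative activity, read by fluorescence, with a stated time of 72 h; on this read-out lower numbers stand for stronger inhibition of growth and higher numbers for weaker inhibition of growth:
- compound 1, `CC(C)c1n[nH]c2c(NCc3ccc(-c4ccccn4)cc3)nc(SCC(O)C(F)(F)F)nc12`: 690 nM
- compound 2, `CC(C)c1n[nH]c2c(NCc3ccc(-c4ccccn4)cc3)nc(SCC(C)(C)N)nc12`: 85 nM

Compound 1 holds the highest of the two numbers in this assay; its nearest neighbour is compound 2, reached by an 8.1-fold lower number from compound 1 to compound 2 (0.91 log units; beyond the scatter), a step that exchanges one chain terminus for another while the chain on the sulfur stays in place.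

Compound 3, `CC(C)c1n[nH]c2c(NCc3ccc(-c4ccccn4)cc3)nc(S)nc12`, has not been measured. Against compound 1 it shows (hydrogen in place of 3,3,3-trifluoro-2-hydroxypropyl on a sulfur). The shared core and the remainder of compound 1 are untouched.

Among the measured compounds shown here, no measured step bears directly on this change: the only step in hand, from compound 1 to compound 2, keeps a three-carbon chain on the sulfur and alters only its terminus, so it says nothing about removing the chain altogether. What can be taken from it is that the sulfur substituent matters to this assay, since a change in its terminus alone moved the number beyond the scatter. With the whole chain gone, a step toward a higher number is expected, of size a 4.3-fold higher number from compound 1 to compound 3 (0.64 log units; beyond the scatter), with wide uncertainty.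

Compound 3 is therefore estimated at 3000 nM, in the range 800 nM to 12000 nM.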

Compound 3, concentration for 50% growth inhibition: 2760 nM
Estimate against measurement, compound 3: 1.1-fold (0.04 log units) above; measured number inside the range.
By their numbers in this assay, from the lowest: compound 2; then compound 1; then compound 3.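

In this assay, removing the whole chain on the sulfur raises the number in both available comparisons: a 4.0-fold higher number from compound 1 to compound 3 (0.60 log units; beyond the scatter) on loss of 3,3,3-trifluoro-2-hydroxypropyl, and a 32-fold higher number from compound 2 to compound 3 (1.51 log units; beyond the scatter) on loss of 2-amino-2-methylpropyl. Both chains therefore give lower numbers than the free sulfanyl form, although the gain differs widely between them, while the shared core with only a sulfanyl group still gives a measurable number, with compound 3 at 2760 nM. No accompanying evidence bears on these differences, and the data assign no reason for them.

The compounds shown leave open how much of the gain belongs to the carbon chain itself and how much to its terminus, a question that a plain propyl chain on the sulfur, carrying no hydroxyl, amine or trifluoromethyl, would address. Also open, from the compounds shown here alone, are the effects of a carboxylic acid terminus, of a longer chain ending in a primary amine, and of an oxygen or nitrogen linker in place of the sulfur.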